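The source may report more compounds than this note shows. Statements on the series, on what has been measured and on what is new or still open speak of the compounds shown alone.

Two compounds already have numbers in a physicochemical assay for lipophilicity, at pH 7.4; a higher number here means a more lipophilic compound, a lower number a more polar compound. Compound 1 `CCc1ccc(N(CC(C)C)S(=O)(=O)c2ccc3c(c2)C(O)CC(C2CCNCC2)O3)cc1` gives 1.04 in this assay. Compound 2 `CC(C)CN(c1ccc(F)cc1)S(=O)(=O)c1ccc2c(c1)C(O)CC(C1CCOCC1)O2` gives 3.39 in this assay, the higher of the two numbers, with compound 1 sitting far below it, well beyond the usual scatter. Compound 3 `Cc1ccc(N(CC(C)C)S(=O)(=O)c2ccc3c(c2)C(O)CC(C2CCOCC2)O3)c(C)c1` has not yet been measured. It differs from compound 2 in one place: 2,4-dimethylphenyl in place of 4-fluorophenyl on a sulfonamide nitrogen. Among the compounds with values here, no measured pair shows this kind of change, so the expectation rests on the change alone: a moderate rise is expected, as a number 0.71 log units higher from compound 2 to compound 3 (beyond the scatter). Compound 3 is therefore estimated at 4.1, expected to fall between 3.6 and 4.6.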

Compound 3, distribution coefficient: 4.19
Estimate against measurement, compound 3: 0.09 log units below; low and high end bracket the measured number.
By their numbers in this assay, from the lowest: compound 1; then compound 2; then compound 3.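

Swapping 4-fluorophenyl for 2,4-dimethylphenyl on a sulfonamide nitrogen gives, in this assay, a number 0.80 log units higher from compound 2 to compound 3 (beyond the scatter) and so shows that this position is not silent. Within the data shown here, compound 2 and compound 3 are the only pair here that differ in one place, so this step can be tied to this one change with the rest of the structure held fixed. Nothing available explains why the number moves this way. Going by these compounds, whether one methyl alone would give the same step stays open. So does how an amine or a carboxylic acid on this phenyl ring would read.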